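A few compounds are considered here, and "the series" means these few. Any claim that something is new, unique, unknown or untested is made for them only; others in the source may bear on it.

Of the compounds shown here, three that share a core have been tested in a functional assay on ovarian cells (Homo sapiens) for antiproliferative activity; on this read-out higher numbers stand for weaker inhibition of growth and lower numbers for stronger inhibition of growth. Compound 1 (`Cc1sc2nc(-c3ccccn3)c(/C=N/NC(=N)N)n2c1C`) gives 37200 nM, compound 2 (`N=C(N)N/N=C/c1c(-c2cc([N+](=O)[O-])c(Cl)cc2Cl)nc2sc(Cl)cn12`) gives 66100 nM, and compound 3 (`N=C(N)N/N=C/c1c(-c2ccccn2)nc2sc(Cl)cn12`) gives 14500 nM. That is the lowest of the three numbers, and both gaps to it lie beyond the scatter. Compound 4 (`N=C(N)N/N=C/c1c(-c2ccncc2)nc2sc(Cl)cn12`) has the same atoms as compound 3, joined differently, with pyridin-4-yl in place of pyridin-2-yl on an aromatic carbon. Among the measured compounds shown here, no measured pair differs in one place only, so this swap has no direct precedent here. In this assay the expected change is a small rise in the number, a 1.4-fold higher number from compound 3 to compound 4 (0.14 log units; within the scatter), staying within the scatter. For compound 4 the estimate is 20000 nM, with an expected range of 8000 nM to 50000 nM.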

Compound 4, concentration for total growth inhibition: 20900 nM
The estimate for compound 4 lay 1.0-fold (0.02 log units) below the measured number; the measured number falls inside the stated range.
By their numbers in this assay, from the lowest: compounds 3, 4, 1 and 2 (each within the scatter of the next, the first and the last beyond it).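

In this assay, pyridin-4-yl in place of pyridin-2-yl on this aromatic carbon gives a 1.4-fold higher number from compound 3 to compound 4 (0.16 log units; within the scatter). This first pair differing in one place only shows that, on this core, the two pyridine attachments cannot be told apart on this read-out. Nothing measured here offers an explanation for this result.

As far as these compounds go, whether pyridin-3-yl, plain phenyl or a pyridine ring carrying an amine would read the same at this carbon stays open. So does whether this swap would give a similar step on the core of compound 1.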